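The source may hold more compounds than are shown below. What is called first, only, known or untested is meant among the compounds shown, and "the series" means these compounds.

Measured so far in a functional assay on HEp-2 cells (Homo sapiens) for cytotoxicity, read by sulforhodamine B assay, with a stated time of 48 h; a higher number here means a weaker inhibitor, a lower number a stronger inhibitor:
compound 1 `COc1cc(C2CC(c3ccco3)=NN2C(C)=O)cc(OC)c1OC` gives 21300 nM
compound 2 `COc1ccc(C2CC(c3ccc4ccccc4c3)=NN2CC=O)cc1OC` gives 1010 nM
compound 3 `COc1ccc(C2CC(c3ccc4ccccc4c3)=NN2CC=O)cc1O` gives 1020 nM

Compound 3 stands second highest of the three numbers. Its nearest neighbour is compound 2: the step from compound 2 to compound 3 is a 1.0-fold higher number from compound 2 to compound 3 (0.00 log units; within the scatter), so the two cannot be told apart. Among the measured compounds shown here, the furthest is compound 1, whose higher number lies beyond the scatter; compound 1, however, differs from compound 3 in several places at once, so no single step can be drawn from it.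

Compound 4 `O=CCN1N=C(c2ccc3ccccc3c2)CC1/C=C/c1ccccc1` differs from compound 3 by 2-phenylethenyl in place of 3-hydroxy-4-methoxyphenyl on a saturated ring carbon. For the measured compounds named here, the one measured single step, from compound 2 to compound 3, touches a different position and lies within the scatter, so it says nothing about this change. Going by the values given here, no measured step bears on exchanging the aromatic ring for 2-phenylethenyl on the saturated ring carbon. The analyst therefore expects no step beyond the scatter, but with wide uncertainty, the expected step being a 1.5-fold higher number from compound 3 to compound 4 (0.17 log units; within the scatter). For compound 4 the estimate is 1500 nM, ranging from 400 nM to 6000 nM.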

Compound 4, half-maximal inhibitory concentration: 20100 nM
Beside the measured number, compound 4's estimate is 13-fold (1.13 log units) below it; measured number outside the range, above it.
By their numbers in this assay, from the lowest: compounds 2 and 3 (each within the scatter of the next); then compounds 4 and 1 (each within the scatter of the next).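

In this assay, the saturated ring carbon next to the ring nitrogen proves responsive to its substituent: putting 2-phenylethenyl in place of 3-hydroxy-4-methoxyphenyl there gives a 20-fold higher number from compound 3 to compound 4 (1.29 log units; beyond the scatter), a large step and a weaker inhibitor. The earlier step, a 1.0-fold higher number from compound 2 to compound 3 (0.00 log units; within the scatter), showed only that removing the methyl from an oxygen on that aromatic ring made no discernible difference; the new step shows that the substituent as a whole is not freely exchangeable, even though an aromatic ring of carbon remains in the entering group. Nothing measured here accounts for the size of this step.

The change removes the hydroxy and methoxy groups and adds a double bond outside aromatic rings in a single exchange, and the compounds shown leave open which of these matters. A plain phenyl, a 2-phenylethyl chain or a 2-phenylethenyl bearing hydroxy and methoxy groups on this carbon would separate the two.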